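Amidine series: trifluoromethyl removed from the anilide ring

The compounds below may be only part of what the source reports. "The series", "measured", "known", "first", "only" and "open" are said of these compounds alone.

Compound 1 `COc1ccc(Cn2cc3cc(C(=N)Nc4cccc(C(F)(F)F)c4)ncc3n2)cc1` holds the lower of the two numbers shown, giving 15500 nM in a functional assay on MDA-MB-231 cells (Homo sapiens) for cytotoxicity, read by MTT assay, with a stated time of 72 h; on this read-out lower numbers stand for stronger inhibition and higher numbers for weaker inhibition; compound 2 `Cn1nc(-c2ccccc2)c2cc(C(=N)Nc3cccc(C(F)(F)F)c3)ncc21` gives 21400 nM, a gap that stays within the usual scatter, so no order between the two is claimed. Compound 3 `COc1ccc(Cn2cc3cc(C(=N)Nc4ccccc4)ncc3n2)cc1` has not yet been measured. The change from compound 1 to compound 3 is hydrogen in place of trifluoromethyl on an aromatic carbon. For the measured compounds named here, no measured pair shows this change; the expected step is a 1.8-fold higher number from compound 1 to compound 3 (0.26 log units; within the scatter), a modest weakening, likely just beyond the scatter. Compound 3 is expected near 28000 nM, within a range of 9000 nM to 90000 nM.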

Compound 3, half-maximal inhibitory concentration: 1520 nM
Compound 3: the middle estimate sits 18-fold (1.27 log units) above what was measured; measured number outside the range, below it.
By their numbers in this assay, from the lowest: compound 3; then compounds 1 and 2 (each within the scatter of the next).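

In this assay, for the compounds shown here, the change from 3-(trifluoromethyl)phenyl to phenyl gives a 10-fold lower number from compound 1 to compound 3 (1.01 log units; beyond the scatter) and is the first single-place step, showing that the number responds strongly to this aromatic position. Compound 1 and compound 2 differ in more than one place, so they could not show this. Nothing at hand gives a reason for the step.

Open, from the compounds shown here alone, is how methyl, fluorine, methoxy or an amine on the same aromatic carbon would compare with hydrogen or trifluoromethyl. Also open, going by these compounds, is whether the same change on the core of compound 2 gives a step of similar size.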